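This account rests on a few compounds, and the source may have more. Where it says the series, first, only, none or still open, it means among the compounds named here.

Values in a physicochemical assay for solubility, using the shake flask method, measured as kinetic solubility, with a stated time of 20 h, at pH 2; a lower number here means a less soluble compound, a higher number a more soluble compound:
- compound 1 `FC(F)(F)c1cccc(-c2nc3cnc(Nc4ccccn4)cc3[nH]2)c1`: 21000 nM
- compound 2 `COc1cccc(Nc2cc3[nH]c(-c4cccc(C(F)(F)F)c4)nc3cn2)n1`: 85000 nM
- compound 3 `COc1ccnc(Nc2cc3[nH]c(-c4cccc(C(F)(F)F)c4)nc3cn2)c1`: < 5000 nM, a limit of the assay

Compound 1 gives the lowest of the two numbers actually read; compound 2 sits above it, a 4.0-fold higher number from compound 1 to compound 2 (0.61 log units; beyond the scatter). For compound 3 the assay reports only a limit (the limit of < 5000 nM in this assay, at which 1 of the 3 values shown sits). Against that limit the step is an at least 4.2-fold lower number from compound 1 to compound 3 (0.62 log units; beyond the scatter), and between the two methoxy isomers it is an at least 17-fold lower number from compound 2 to compound 3 (1.23 log units; beyond the scatter).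

Compound 4 `FC(F)(F)c1cccc(-c2nc3cnc(Nc4ccc(-c5nnn[nH]5)cn4)cc3[nH]2)c1` differs from compound 1 by 1H-tetrazol-5-yl in place of hydrogen on an aromatic carbon. Among the measured compounds shown here, none of the measured steps places a 1H-tetrazol-5-yl anywhere on the core, so none bears on this change directly. The two steps that do start from compound 1 run in opposite directions, upward in a 4.0-fold higher number from compound 1 to compound 2 (0.61 log units; beyond the scatter) and downward in an at least 4.2-fold lower number from compound 1 to compound 3 (0.62 log units; beyond the scatter), and together they show only that a small substituent on this ring can move the number well beyond the scatter either way. No direction can be drawn from them for a 1H-tetrazol-5-yl. The expectation for compound 4 is therefore a number close to compound 1, with a wide band: 20000 nM, between 5000 nM and 80000 nM, which corresponds to an expected step of a 1.1-fold lower number from compound 1 to compound 4 (0.02 log units; within the scatter).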

Compound 4, solubility: < 5000 nM
Compound 4: a limit, no number; the forecaster's own chance of this, stated with the estimate: 20%; middle value at least 4.0-fold (0.60 log units) away from the limit.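

In this assay compound 4 gives < 5000 nM as a limit and not a number: the limit of < 5000 nM in this assay, at which 2 of the 4 values shown sit.
Placing 1H-tetrazol-5-yl on an aromatic carbon two atoms from the ring nitrogen, para to a large group, gives an at least 4.2-fold lower number from compound 1 to compound 4 (0.62 log units; beyond the scatter) and so counts as a downward move, though its full size stays hidden behind the limit. The methoxy steps gave no reading for a five-membered aromatic ring with 4 hetero atoms, and this change now supplies one, in a single direction.

On these data alone, whether this fall belongs to the 1H-tetrazol-5-yl itself or to substitution at this carbon in general stays open, and a carboxylic acid, an amine or a nitrile on the same carbon would separate the two. How compound 3 and compound 4 order beneath the shared limit cannot be read.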